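Paw edema inhibition series: working notes toward compound 3

The source may hold more compounds than are shown below. What is called first, only, known or untested is meant among the compounds shown, and "the series" means these compounds.

Measured so far:
compound 1 `Cc1ccc(-c2cc(C(=O)Oc3ccc(C(C)C)cc3)n(Cc3ccccc3)n2)cc1`: 24%
compound 2 `CCCCCCCOc1ccc(OC(=O)c2cc(-c3ccc(C)cc3)nn2Cc2ccccc2)cc1`: 9%

In a functional assay on the whole organism (strain Swiss albino) for inhibition, with Mus musculus as the target, read by paw edema, with stated times of 30 min and 180 min, at a dose of 100 mg/kg by the subcutaneous route (a higher number here means more inhibition at the dose given (going by the name of the read-out), a lower number less inhibition), compound 1 gives 24% and compound 2 gives 9%. Among the compounds with values here, compound 2 stands lowest of the two numbers, with compound 1 as its only neighbour. Within the data shown here, the single measured step, a number 15 percentage points lower from compound 1 to compound 2 (beyond the scatter), is the sole point of reference. Compound 3 `Cc1ccc(-c2cc(C(=O)Oc3ccc(-n4ccnc4)cc3)n(Cc3ccccc3)n2)cc1` differs from compound 2 thus: 1H-imidazol-1-yl in place of heptyloxy on an aromatic carbon. Among the measured compounds shown here, that step bears only indirectly: it shows heptyloxy leaving compound 2 at the low end, but no measured compound carries 1H-imidazol-1-yl, so the size of the change is unset. Compound 3 is expected to recover part of the way toward compound 1, a step of a number 9 percentage points higher from compound 2 to compound 3 (within the scatter), to an estimated 18% within 5% to 35%.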

Compound 3, a percentage reported as inhibition, in the whole organism at one dose (the size of the read-out at that dose, not a potency): 15.4%
Compound 3: the middle estimate sits 2.6 percentage points above what was measured; the range from low to high includes it.
By their numbers in this assay, from the lowest: compounds 2, 3 and 1 (each within the scatter of the next, the first and the last beyond it).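

In this assay the swap of heptyloxy for 1H-imidazol-1-yl gives a number 6.4 percentage points higher from compound 2 to compound 3 (within the scatter) and the swap of isopropyl for 1H-imidazol-1-yl gives a number 8.6 percentage points lower from compound 1 to compound 3 (within the scatter) so compound 3 cannot be told apart from either neighbour, even though compound 1 and compound 2 stay apart. At this position a five-membered aromatic ring with 2 hetero atoms therefore reads like both the branched and the long chain. Nothing at hand gives a reason for this reading.

Still open, from the compounds shown here alone, is whether a carboxylic acid or a dimethylamino group on this aromatic carbon would move the number clearly beyond that of compound 1.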